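The source may hold more compounds than are shown below. What is called first, only, known or untested is meant among the compounds shown, and "the series" means these compounds.

Measured so far:
compound 1, `CCOC(=O)/C=C(C)/C=C/CC(C)CCCC(C)(C)OC`, 5.54
compound 2, `COC(C)(C)CCCC(C)C/C=C/C(C)=C/C(=O)OC(C)(C)C`, 6.36

In a physicochemical assay for lipophilicity (a higher number here means a more lipophilic compound, a lower number a more polar compound), compound 1 stands lowest of the two measured numbers. Its nearest neighbour is compound 2, which gives a number 0.82 log units higher from compound 1 to compound 2 (beyond the scatter); the change behind that step is tert-butyl in place of ethyl on an oxygen next to a carbonyl group, at the ester end of the shared core.

Compound 3, `CCOC(=O)/C=C(C)/C=C/CC(C)CCC(SCC)C(C)C`, has not yet been measured in this assay. It differs from compound 1 at the other end of the chain: 1-(ethylsulfanyl)-2-methylpropyl in place of 2-methoxy-2-methylpropyl on a saturated chain carbon, four bonds along the chain from a double-bonded chain carbon.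

For the measured compounds named here, the single measured step, from compound 1 to compound 2, touches the ester end and leaves the saturated chain end untouched, so it does not bear directly on this change. What it does show is that a single modest exchange of a small group has moved this assay beyond the scatter here. For compound 3 the expectation is a step upward, a number 0.96 log units higher from compound 1 to compound 3 (beyond the scatter), beyond the scatter. The estimate for compound 3 in this assay is 6.5, with a range from 5.9 to 7.1.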

Compound 3, partition coefficient: 6.9
Compound 3: middle estimate off by 0.40 log units, on the low side; the range from low to high includes it.
By their numbers in this assay, from the lowest: compound 1; then compound 2; then compound 3.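

In this assay the exchange at the saturated chain end gives a number 1.36 log units higher from compound 1 to compound 3 (beyond the scatter), so this end of the molecule, left untouched in the earlier step, also moves the number beyond the scatter. That step is graded large, whereas the step at the ester end, a number 0.82 log units higher from compound 1 to compound 2 (beyond the scatter), is graded modest, so both ends of the chain respond in this assay and the grade here is the higher of the two. The exchange alters several things at once, with sulfur entering where oxygen leaves and the carbon count changing too, and no supporting measurement is available to assign the step to any one of these parts.

Still open, as far as these compounds go, is whether the sulfur or the added carbon carries most of the step, a question that a 1-(ethylsulfanyl)-2-methylpropyl analogue with oxygen in place of the sulfur could help to separate. Also open, from the compounds shown here alone, is how this assay would respond to a group of a different kind at this chain end, such as an amine or a carboxylic acid.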